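This account rests on a few compounds, and the source may have more. Where it says the series, first, only, none or still open, it means among the compounds named here.

Measured so far:
compound 1 `O=C(NCc1ccc(S(=O)(=O)c2cncc(C(F)(F)F)c2)cc1)N1Cc2ccncc2C1` — 83000 nM
compound 2 `CC(C)n1cc(S(=O)(=O)c2ccc(CNC(=O)N3Cc4ccncc4C3)cc2)cn1` — 192000 nM

In a physicochemical assay for solubility, in phosphate buffer, with a stated time of 24 h, at pH 7.4, tested at 100 uM (on this read-out lower numbers stand for lower solubility and higher numbers for higher solubility), compound 1 gives 83000 nM, the lower of the two numbers; in this assay compound 2 gives 192000 nM, and the step is a 2.3-fold higher number from compound 1 to compound 2 (0.36 log units; beyond the scatter). Compound 3 `O=C(NCc1ccc(S(=O)(=O)N2CCC[C@H](O)C2)cc1)N1Cc2ccncc2C1` has not yet been measured. It differs from compound 1 as follows: 3-hydroxypiperidin-1-yl in place of 5-(trifluoromethyl)pyridin-3-yl on a sulfonyl sulfur. Within the data shown here, the one measured step that bears on this is the exchange at the same sulfonyl sulfur, a 2.3-fold higher number from compound 1 to compound 2 (0.36 log units; beyond the scatter), which was a modest rise beyond the scatter. Among the measured compounds shown here, the entering group here is a non-aromatic ring carrying one hydrogen-bond donor rather than another aromatic ring, so the direction is taken from the single comparison available and the size is uncertain. For compound 3 a rise in this assay is expected, a 2.0-fold higher number from compound 1 to compound 3 (0.31 log units; beyond the scatter). The estimate for compound 3 is 170000 nM, with a range from 90000 nM to 320000 nM.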

Compound 3, solubility: 215000 nM
For compound 3 the middle estimate is 1.3-fold (0.10 log units) below the measured one; the measured number falls inside the stated range.
By their numbers in this assay, from the lowest: compound 1; then compounds 2 and 3 (each within the scatter of the next).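

In this assay, the sulfonyl sulfur position now also accepts a non-aromatic ring: 3-hydroxypiperidin-1-yl in place of 5-(trifluoromethyl)pyridin-3-yl gives a 2.6-fold higher number from compound 1 to compound 3 (0.41 log units; beyond the scatter). Exchanging 1-isopropyl-1H-pyrazol-4-yl for the same ring gives a 1.1-fold higher number from compound 2 to compound 3 (0.05 log units; within the scatter), so the step away from compound 1 reaches the same level with an aromatic or a non-aromatic entering ring, at least in these compounds. No measurement available here accounts for either step.

Open, from the compounds shown here alone, is what a plain piperidin-1-yl, a morpholine or the opposite stereoisomer of the 3-hydroxypiperidin-1-yl group would give, so the share of the hydroxyl in the step remains unresolved. Also open, going by these compounds, is whether a ring carrying an amine or a carboxylic acid at this sulfonyl sulfur would move the number beyond the level shared by compound 2 and compound 3.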